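This account rests on a few compounds, and the source may have more. Where it says the series, first, only, none or still open, it means among the compounds named here.

The series shares an aminophenyl amide core and a thioether-linked benzyl arm, varied at the aryl group on the sulfur and in the linker to the amide. Compound 1 `COc1ccc(SCc2ccc(C(=O)Nc3ccccc3N)cc2)cc1` and compound 2 `Nc1ccccc1NC(=O)c1ccc(CSc2cccc(F)c2)cc1` carry the amide directly on the ring. In a functional assay on SMMC-7721 cells (Homo sapiens) for antiproliferative activity, read by CCK-8 assay, with a stated time of 72 h (on this read-out higher numbers stand for weaker inhibition and lower numbers for stronger inhibition), compound 1 gives 2170 nM, and compound 2 gives 3280 nM. For the measured compounds named here, the only step between measured compounds is a 1.5-fold higher number from compound 1 to compound 2 (0.18 log units; within the scatter), so swapping the aryl group on the sulfur left the read-out essentially unchanged.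

Compound 3 `CC(C)(C)c1ccc(SCc2ccc(/C=C/C(=O)Nc3ccccc3N)cc2)cc1` extends the linker with a propenoyl unit and bears a 4-(tert-butyl)phenyl on the sulfur; in this assay compound 3 gives "not determined" (no result reported), so compound 3 stands nowhere on the numbers at hand. Compound 4 `Nc1ccccc1NC(=O)/C=C/c1ccc(CSCCc2ccccc2)cc1` differs from it as follows: phenethyl in place of 4-(tert-butyl)phenyl on a sulfur.

Going by the values given here, no measured step involves the extended linker or a saturated arm on the sulfur, so the step from compound 1 to compound 2 bears on the question only in showing that the group on the sulfur had little effect there. For compound 4 the expectation is therefore a number near the two measured compounds, with no direction to the change and a wide range to reflect the absence of a direct comparison. Compound 4 is estimated at 3000 nM, expected between 700 nM and 13000 nM.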

Compound 4, half-maximal inhibitory concentration: 10900 nM
The estimate for compound 4 lay 3.6-fold (0.56 log units) below the measured number; measured number inside the range.
By their numbers in this assay, from the lowest: compounds 1 and 2 (each within the scatter of the next); then compound 4.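

Compound 3 carries no number in this assay and so the step from it to compound 4, phenethyl in place of 4-(tert-butyl)phenyl on the sulfur, cannot be read. No evidence on hand bears on the result for compound 4. The compounds shown leave open how the propenoyl linker and the phenethyl group each bear on the read-out.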